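A Bromophenyl Swap at the Cytotoxicity Limit

A few compounds are considered here, and "the series" means these few. Any claim that something is new, unique, unknown or untested is made for them only; others in the source may bear on it.

In an ADME assay on HEK293 cells (Homo sapiens) for cytotoxicity, with a stated time of 72 h (a higher number here means that more compound is needed for the effect, a lower number that less compound is needed), compound 1 `C=C[C@@](C)(/C=C/c1ccc(OC)cc1)CCC=C(C)C` gives > 36600 nM as a limit. Compound 2 `C=C[C@@](C)(/C=C/c1ccc(-c2ccccc2)cc1)CCC=C(C)C` gives > 36600 nM as a limit. Compound 3 `C=C[C@@](C)(/C=C/c1ccc(-c2ccc(Cl)cc2)cc1)CCC=C(C)C` gives > 36600 nM as a limit, so its place is known only as a limit. Compound 4 `C=C[C@@](C)(/C=C/c1ccc(-c2cccc(Br)c2)cc1)CCC=C(C)C` carries 3-bromophenyl in place of 4-chlorophenyl on an aromatic carbon in this series. Going by the values given here, the steps that bear on it are a step that the two limits leave unreadable from compound 2 to compound 3 and a step that the two limits leave unreadable from compound 1 to compound 3 and also a step that the two limits leave unreadable from compound 1 to compound 2 here. None gives a readable size because of the limit of > 36600 nM in this assay, at which 3 of the 3 values shown sit, in these data. The expected change is a number no higher from compound 3 to compound 4 (the limit leaves the size open) with no size beyond the scatter foreseen in this assay for this swap. For compound 4 the estimated value is 36600 nM within an expected range of 18000 nM to 60000 nM overall.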

Compound 4, half-maximal effective concentration: > 36600 nM
Compound 4: only a limit was reported; the forecaster's own chance of this, stated with the estimate: 85%; the middle value lies on the limit itself.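

In this assay compound 4 gives > 36600 nM, which is a limit. No step to compound 4 from compound 1, compound 2 or compound 3 can be read: the limit of > 36600 nM in this assay, at which 4 of the 4 values shown sit.

The compounds shown leave open how far these four actually differ in this assay, and at what concentration any of them would reach the half-maximal effect.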